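Swapping an Amine Arm for an Imine in Paw Edema

The compounds below may be only part of what the source reports. "The series", "measured", "known", "first", "only" and "open" are said of these compounds alone.

Measured so far:
Compound 1 `N#CC1=C(NC(=O)c2ccccc2O)N(c2ccccc2)C(=O)N2CCCCC(N3CCCC3)C12`: 65.4%
Compound 2 `N#CC1=C(NCN2CCCCC2)N(c2ccccc2)C(=O)N2CCCCC(N3CCCC3)C12`: 42.1%

In a functional assay on the whole organism (strain albino) for inhibition, with Rattus norvegicus as the target, read by paw edema, with stated times of 1 h and 3 h, at a dose of 20 mmol/kg by the intraperitoneal route (a higher number here means a stronger effect of the compound at the dose given, a lower number a weaker effect), compound 1 reaches 65.4%. Going by the values given here, compound 2 is the weaker of the two, giving 42.1% in this assay, and the single measured step, a number 23.3 percentage points lower from compound 1 to compound 2 (beyond the scatter), is the only guide available.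

Compound 3 `N#CC1=C(/N=C/c2ccccc2)N(c2ccccc2)C(=O)N2CCCCC(N3CCCC3)C12` is the unmeasured partner of compound 2. The change is a group of 8 heavy atoms (7 carbon, 1 nitrogen; one six-membered aromatic ring of carbon only) in place of a group of 8 heavy atoms (6 carbon, 2 nitrogen; one six-membered non-aromatic ring with 1 hetero atom), on a double-bonded ring carbon, placed on a double-bonded ring carbon of the shared core, next to the ring nitrogen and next to the ring atom that bears a cyano group.

The measured step bears on this only loosely: it shows that what sits on this ring carbon matters, since replacing an aromatic-bearing carbonyl by a saturated amine arm cost a modest amount. Compound 3 brings an aromatic ring back, but without the carbonyl and hydroxyl of compound 1, so a recovery toward compound 1 is plausible yet uncertain. For compound 3 the expected step is a number 7.9 percentage points higher from compound 2 to compound 3 (within the scatter), small and possibly within the scatter. Compound 3 is therefore estimated at 50%, between 32% and 68%.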

Compound 3, a percentage reported as inhibition, in the whole organism at one dose (the size of the read-out at that dose, not a potency): 84%
Compound 3: the middle estimate sits 34 percentage points below what was measured; measured number above the stated range.
By their numbers in this assay, from the lowest: compound 2; then compound 1; then compound 3.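

At this ring carbon, the outcome in this assay depends strongly on the group attached: replacing the ((piperidin-1-yl)methyl)amino arm with the imine-linked aromatic ring gives a number 41.9 percentage points higher from compound 2 to compound 3 (beyond the scatter). The carbonyl and hydroxyl of compound 1 are also not needed for a strong effect at this dose, since the group without them gives a number 18.6 percentage points higher from compound 1 to compound 3 (beyond the scatter), so among these three compounds, the two with a six-membered aromatic ring of carbon only at this place stand above compound 2, and the one with the double-bonded link and no hydrogen-bond donor in this group stands highest. No measurement here explains why the effect rises with this change.

The gain from compound 2 to compound 3 comes with both a new aromatic ring and a new double bond, and the compounds shown cannot separate the two changes. A cyclohexyl group on the same double-bonded link would test the need for the aromatic ring, while a methoxy group on the phenyl ring would show whether the ring accepts further substitution.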